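Replacing a Selenium-Bearing Chain with 2-Aminoethoxy

This account rests on a few compounds, and the source may have more. Where it says the series, first, only, none or still open, it means among the compounds named here.

Of the compounds shown here, three sharing one core have been measured in a functional assay on HCT-116 cells (Homo sapiens) for inhibition, read by MTT assay, with a stated time of 48 h; a higher number here means a weaker inhibitor, a lower number a stronger inhibitor. Compound 1 `COc1ccc(N(C)c2nc(C)nc3ccccc23)cc1C(=O)OCC[Se]C#N` gives 951 nM, the second highest of the three numbers. Compound 3 `Cc1nc(N(C)c2ccc([Se]C#N)c(Cl)c2)c2ccccc2n1` gives 12 nM, the lowest number, while compound 2 `COc1ccc(N(C)c2nc(C)nc3ccccc23)cc1OCCCCCC[Se]C#N` gives 6180 nM, the highest. Compound 4 `COc1ccc(N(C)c2nc(C)nc3ccccc23)cc1OCCN` has not yet been measured. It differs from compound 1 in one place: a group of 4 heavy atoms (2 carbon, 1 nitrogen, 1 oxygen; no ring) in place of a group of 8 heavy atoms (4 carbon, 1 nitrogen, 2 oxygen, 1 selenium; no ring), on an aromatic carbon. Within the data shown here, the only measured step that touches the same place is the one in which one selenium-bearing chain was swapped for another, giving a 6.5-fold higher number from compound 1 to compound 2 (0.81 log units; beyond the scatter). Among the measured compounds shown here, no measured step removes the selenium-bearing part altogether, as the change to compound 4 does, so the expectation rests on the modest weakening seen in that step and on compound 3, the compound with the lowest number, keeping such a group. Compound 4 is therefore expected to be somewhat weaker, with an estimated step of a 3.7-fold higher number from compound 1 to compound 4 (0.57 log units; beyond the scatter). Compound 4 is estimated to give 3500 nM in this assay, in a range from 900 nM to 14000 nM.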

Compound 4, half-maximal inhibitory concentration: 198 nM
Compound 4: middle estimate off by 18-fold (1.25 log units), on the high side; measured number below the stated range.
By their numbers in this assay, from the lowest: compound 3; then compound 4; then compound 1; then compound 2.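

In this assay, the selenium-bearing chain is not needed for a low number at this position: replacing it with 2-aminoethoxy gives a 4.8-fold lower number from compound 1 to compound 4 (0.68 log units; beyond the scatter). Measured against the longer selenium-bearing chain, the same group gives a 31-fold lower number from compound 2 to compound 4 (1.49 log units; beyond the scatter), the largest step seen at this place, so both selenium-bearing chains shown here give higher numbers than the smaller group without selenium. Nothing available explains why the smaller group gives the lower number.

On these data alone, it remains open whether the amine itself matters, which a 2-hydroxyethoxy or plain ethoxy group in its place would test, and whether a longer chain ending in an amine would do as well. As far as these compounds go, compound 3 differs from these compounds in more than one place, so the contribution of its selenium-bearing group also remains open.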